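The source may hold more compounds than are shown below. What is called first, only, known or untested is meant among the compounds shown, and "the series" means these compounds.

Working notes on the series.

Three analogues of the shared core carrying a carboxylic acid have been measured in an assay on cells for inhibition of Palmitoleoyl-protein carboxylesterase NOTUM variant C330S (Homo sapiens), read by fluorescence, with a stated time of 40 min; on this read-out higher numbers stand for weaker inhibition and lower numbers for stronger inhibition. Compound 1 `Cc1ccccc1-n1c(C)cc(C(=O)O)c1C` gives 2200 nM. Compound 2 `Cc1ccc(-n2c(C)cc(C(=O)O)c2C)cc1` gives 2000 nM. Compound 3 `Cc1cc(C(=O)O)c(C)n1-c1ccccc1Cl` gives 2300 nM. The three numbers sit within the scatter of one another, so none of the three can be set apart from the others on this read-out. Compound 1 and compound 2 carry the same atoms joined differently; the difference between the two cores is not broken down here.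

Compound 3 arises from compound 1 by chloro in place of methyl on an aromatic carbon. This change gave a 1.0-fold higher number from compound 1 to compound 3 (0.02 log units; within the scatter).

The unmeasured compound 4 `Cc1cc(C(=O)O)c(C)n1-c1ccc(Cl)cc1` arises from compound 2 by the same kind of change, (chloro in place of methyl on an aromatic carbon). The place is not identical: in compound 3 the chloro sits ortho to a large group, in compound 4 it sits para to a large group, so the two changes are the same kind of change rather than the same.

For compound 4 in this assay a step of about a 1.1-fold higher number from compound 2 to compound 4 (0.02 log units; within the scatter) is expected, beside the earlier one of a 1.0-fold higher number from compound 1 to compound 3 (0.02 log units; within the scatter), because a 1.0-fold higher number from compound 1 to compound 3 (0.02 log units; within the scatter) stayed within the scatter and compound 2 itself gives 2000 nM, a number close to that of compound 1. The estimate for compound 4 is 2100 nM, with a range from 1000 nM to 4500 nM. This rests on one matched step only, so the range is kept wide.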

Compound 4, half-maximal inhibitory concentration: 860 nM
The estimate for compound 4 lay 2.4-fold (0.39 log units) above the measured number; measured number below the stated range.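

In this assay the change of methyl to chloro on the core of compound 2 gave a 2.3-fold lower number from compound 2 to compound 4 (0.37 log units; beyond the scatter), a step beyond the scatter, while the same kind of change on the core of compound 1 gave a 1.0-fold higher number from compound 1 to compound 3 (0.02 log units; within the scatter), a step within it. The larger step on one core therefore does not establish that the two cores respond differently to this change, and the gap between the two steps is no firm sign that the change fails to carry across: the same change on two cores in this assay, a 1.0-fold higher number (0.02 log units; within the scatter) from compound 1 to compound 3 and a 2.3-fold lower number (0.37 log units; beyond the scatter) from compound 2 to compound 4, 2.4-fold (0.39 log units) apart, within the scatter of two such steps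

Within the data shown here, equally, this does not show that the change carries over with a step of constant size, since there is only one matched pair on each core and the place of the change is not the same in the two pairs, so no rule for moving it from one core to another can be drawn.

The compounds shown leave open whether the step seen for chloro para to a large group extends to other groups at that place, such as fluoro, methoxy or trifluoromethyl. They also leave open whether the step persists when the carboxylic acid of the shared core is replaced by an amide.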